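This account rests on a few compounds, and the source may have more. Where it says the series, first, only, none or still open, it means among the compounds named here.

The series rests on a shared core whose six-membered aromatic ring with two nitrogens carries an aryl group on an aromatic nitrogen. Compound 1 `O=C(Nc1ccc(Oc2ccnc3[nH]ccc23)cc1)c1nn(-c2ccc(Br)cc2F)ccc1=O` bears the 4-bromo-2-fluorophenyl group there, and in a functional assay on A549 cells (Homo sapiens) for cytotoxicity, read by MTT assay, with a stated time of 72 h (a lower number here means a stronger inhibitor, a higher number a weaker inhibitor), compound 1 gives 26100 nM. Compound 2 `O=C(Nc1ccc(Oc2ccnc3[nH]ccc23)cc1)c1nn(-c2ccc(Cl)c(F)c2)ccc1=O` differs from it in one place, (4-chloro-3-fluorophenyl in place of 4-bromo-2-fluorophenyl on an aromatic nitrogen), and in this assay compound 2 gives 2580 nM. The change produces a 10-fold lower number from compound 1 to compound 2 (1.01 log units; beyond the scatter).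

Compound 3 `Cn1ccc2c(Oc3ccc(NC(=O)c4nn(-c5ccc(Br)cc5F)ccc4=O)cc3F)ccnc21` keeps the 4-bromo-2-fluorophenyl group but sits on a different core; how its core differs from that of compound 1 is not broken down here. In this assay compound 3 gives 26800 nM, and this value and that of compound 1 lie within the scatter of each other, so nothing separates the two.

Compound 4 `Cn1ccc2c(Oc3ccc(NC(=O)c4nn(-c5ccc(Cl)c(F)c5)ccc4=O)cc3F)ccnc21` has not yet been measured. Within the data shown here, it differs from compound 3 by 4-chloro-3-fluorophenyl in place of 4-bromo-2-fluorophenyl on an aromatic nitrogen, the same change at the same place as the one that turns compound 1 into compound 2. Among the measured compounds shown here, only one earlier instance of this change is available, so the expectation leans on it alone. Because the same change gave a 10-fold lower number from compound 1 to compound 2 (1.01 log units; beyond the scatter), the expected step is an 8.4-fold lower number from compound 3 to compound 4 (0.92 log units; beyond the scatter). In this assay compound 4 is therefore estimated to give about 3200 nM, most likely falling between 1000 nM and 11000 nM.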

Compound 4, half-maximal inhibitory concentration: > 60000 nM
Compound 4 ended at the assay's limit; the forecaster's own chance of this, stated with the estimate: 3%; middle value at least 18-fold (1.27 log units) from the limit.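

On the core of compound 3, 4-chloro-3-fluorophenyl in place of 4-bromo-2-fluorophenyl gives an at least 2.2-fold higher number from compound 3 to compound 4 (0.35 log units; beyond the scatter) in this assay, so the change does not act alike on the two cores and its direction reverses: the same change on two cores in this assay, a 10-fold lower number (1.01 log units; beyond the scatter) from compound 1 to compound 2 and an at least 2.2-fold higher number (0.35 log units; beyond the scatter) from compound 3 to compound 4, at least 22-fold (1.35 log units) apart, beyond the scatter of two such steps. The reading for compound 4, > 60000 nM, is a limit of the assay and not a number. With a single pair on each core, this shows that the outcome of the change depends on the core in these four compounds, but it does not show how large the step on the second core really is, nor which part of the difference between the cores is responsible.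

Going by these compounds, each core carries only these two aryl groups here, so it stays open whether an unsubstituted phenyl or a 4-methoxyphenyl group on the same aromatic nitrogen would follow compound 1 and compound 2 or compound 3 and compound 4. Also open, on these data alone, is how a compound carrying only part of the difference between the two cores would read, and so which part of the core governs the reversal.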